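Swapping a Butyl for a Tert-Butyl at the Branch Carbon

The source may hold more compounds than are shown below. What is called first, only, known or untested is meant among the compounds shown, and "the series" means these compounds.

Measured so far in an assay on isolated protein for inhibition of Lon protease homolog, mitochondrial (Homo sapiens), read by HTRF, with a stated time of 50 min, in the presence of a further agent that is not named here; on this read-out higher numbers stand for weaker inhibition and lower numbers for stronger inhibition:
- compound 1, `CC(C)C[C@H](NC(=O)[C@@H](C)NC(=O)c1cnccn1)B(O)O`, gives 433 nM
- compound 2, `CCCC[C@@H](NC(=O)c1cnccn1)C(=O)N[C@@H](CC(C)C)B(O)O`, gives 93 nM

Compound 2 gives the lowest number of the two, and so the stronger inhibition, in this assay. For the measured compounds named here, the only measured step connects the two: a 4.7-fold lower number from compound 1 to compound 2 (0.67 log units; beyond the scatter). Going from compound 2 to compound 3, `CC(C)C[C@H](NC(=O)[C@H](NC(=O)c1cnccn1)C(C)(C)C)B(O)O`, the chain on the branching carbon is rearranged: tert-butyl in place of butyl on a saturated chain carbon bound to an amide-type nitrogen and a carbonyl carbon. Going by the values given here, the single measured step concerns adding a chain where there was none, not reshaping a chain of the same size, so it bears only loosely on this change; it shows at most that this position tolerates a carbon group and rewards it modestly. Among the compounds with values here, no measured pair tells whether a compact branched group behaves like a straight one here. The expectation is therefore for compound 3 to land close to compound 2 in this assay, with a small estimated shift of a 1.6-fold higher number from compound 2 to compound 3 (0.21 log units; within the scatter). Compound 3 is estimated at 150 nM, within a range of 40 nM to 550 nM.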

Compound 3, half-maximal inhibitory concentration: 2850 nM
Estimate against measurement, compound 3: 19-fold (1.28 log units) below; the whole stated range lies below it.
By their numbers in this assay, from the lowest: compound 2; then compound 1; then compound 3.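

In this assay the shape of the group on this carbon counts, not only its size: butyl and tert-butyl have the same atoms, joined differently, yet tert-butyl in place of butyl gives a 31-fold higher number from compound 2 to compound 3 (1.49 log units; beyond the scatter). The earlier step suggested that a larger carbon group at this position lowers the number, but tert-butyl in place of methyl gives a 6.6-fold higher number from compound 1 to compound 3 (0.82 log units; beyond the scatter), so compound 3 goes against that trend and adding carbon does not by itself strengthen inhibition here. Nothing available explains why this rearrangement of the chain costs so much inhibition.

Still open, as far as these compounds go, is how much branching this position accepts, since an isopropyl group or an isobutyl chain on the same carbon would sit between the straight butyl and the compact tert-butyl and could show where the number begins to climb. Also open, from the compounds shown here alone, is whether a longer chain such as pentyl would lower the number further than butyl, and whether an amine or a carboxylic acid at the end of the butyl chain would be accepted.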